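Adding a Second Bromo Group to Compound 1

The source may hold more compounds than are shown below. What is called first, only, known or untested is meant among the compounds shown, and "the series" means these compounds.

Compound 1 `Cc1cccc2c(CNc3nc(-c4cc5cc(Br)ccc5oc4=O)cs3)cc(=O)[nH]c12` was tested in a functional assay on the whole organism for inhibition, with Rattus norvegicus as the target, read by paw edema, in the formalin test, with a stated time of 12 h, at a dose of 100 mg/kg by the intraperitoneal route (on this read-out higher numbers stand for more inhibition at the one dose given (going by the name of the read-out) and lower numbers for less inhibition), where compound 1 gives 24.1%. Compound 3 `O=c1cc(CNc2nc(-c3cc4cc(Br)ccc4oc3=O)cs2)c2ccc(Cl)cc2[nH]1` gives 23.2% and compound 2 `O=c1cc(CNc2nc(-c3cc4cc(Br)cc(Br)c4oc3=O)cs2)c2ccc(Cl)cc2[nH]1` gives 18.7%; all three numbers lie within the scatter of one another, with compound 1 nearest to compound 3 and furthest from compound 2. Compound 4 `Cc1cccc2c(CNc3nc(-c4cc5cc(Br)cc(Br)c5oc4=O)cs3)cc(=O)[nH]c12` differs from compound 1 by bromo in place of hydrogen on an aromatic carbon. Within the data shown here, the one measured step that bears on this is the reverse of the same change, a number 4.5 percentage points higher from compound 2 to compound 3 (within the scatter), which stayed within the scatter. The change in the opposite direction is therefore expected to move the number little, so that the step of a number 4.1 percentage points lower from compound 1 to compound 4 (within the scatter) is estimated to remain within the scatter. Compound 4 is thus expected to give about 20%, in the range 10% to 30%.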

Compound 4, a percentage reported as inhibition, in the whole organism at one dose (the size of the read-out at that dose, not a potency): 16.7%
Compound 4: middle estimate off by 3.3 percentage points, on the high side; the measured number falls inside the stated range.
By their numbers in this assay, from the lowest: compounds 4, 2, 3 and 1 (each within the scatter of the next).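

Bromo in place of hydrogen, ortho to a fused ring, now has a step of its own in this assay, a number 7.4 percentage points lower from compound 1 to compound 4 (within the scatter). The change had been seen on one core only, and it now stays within the scatter on two, with no difference between the cores that can be told apart: the same change on two cores in this assay, a number 4.5 percentage points higher (within the scatter) from compound 2 to compound 3 and a number 7.4 percentage points higher (within the scatter) from compound 4 to compound 1, 2.9 percentage points apart, within the scatter of two such steps

Only hydrogen and bromo are shown at this position, so what an amine, a methoxy group or a carboxylic acid would do there remains open. As far as these compounds go, whether any group at this position can move the number beyond the scatter also remains open.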